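Trifluoromethoxy in place of nitro: working notes on compound 3

The source may report more compounds than this note shows. Statements on the series, on what has been measured and on what is new or still open speak of the compounds shown alone.

Compound 1 `Cc1cc(NC(=O)Nc2cccc([N+](=O)[O-])c2)c2ccccc2n1` gives > 25000 nM in an ADME assay on HepG2 cells (Homo sapiens) for cytotoxicity, with a stated time of 72 h (a lower number here means that less compound is needed, a higher number that more compound is needed for the effect), and this is a limit of the assay, not a number. Among the compounds with values here, compound 2 `Cc1cc(NC(=O)Nc2ccc(OC(F)(F)F)cc2)c2ccccc2n1` gives 15000 nM in this assay, the only actual number so far. Compound 3 `Cc1cc(NC(=O)Nc2cccc(OC(F)(F)F)c2)c2ccccc2n1` keeps the core of compound 1 and carries trifluoromethoxy in place of nitro on an aromatic carbon, meta to a large group: trifluoromethoxy in place of nitro on an aromatic carbon. Within the data shown here, no measured step speaks to this change, so the expectation rests on compound 2 alone, which also carries trifluoromethoxy and gives 15000 nM. A small step toward lower numbers in this assay is expected, possibly none beyond the scatter, and the reading may again end as a limit. The expected step is an at least 1.3-fold lower number from compound 1 to compound 3 (0.14 log units; that floor lies within the scatter). For compound 3 the estimate is 18000 nM, with an expected range of 9000 nM to 30000 nM.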

Compound 3, half-maximal effective concentration: 13000 nM
Compound 3: the middle estimate sits 1.4-fold (0.14 log units) above what was measured; measured number inside the range.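

In this assay, trifluoromethoxy in place of nitro on an aromatic carbon, meta to a large group, gives an at least 1.9-fold lower number from compound 1 to compound 3 (0.28 log units; that floor lies within the scatter). This is a floor and not a size, so the change is not shown to do more than the scatter allows, and the reading for compound 1 is a limit of the assay and not a number: the limit of > 25000 nM in this assay, at which 1 of the 3 values shown sits.

What compound 3 adds is a real number for this position, and the two compounds carrying trifluoromethoxy now read alike: compound 2 gives 15000 nM and compound 3 gives 13000 nM, values within the scatter of each other.

Going by these compounds, the true size of the step from nitro remains open. Also open, on these data alone, is how other groups at this position, such as an amine or a carboxylic acid, would read in this assay.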